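Methyl on the Phenyl Ring: From Compound 3 to Compound 4

The compounds below may be only part of what the source reports. "The series", "measured", "known", "first", "only" and "open" are said of these compounds alone.

The shared core of these compounds is an alkyne-linked aryl attached to a bicyclic lactam. Compound 1 `Cc1ccccc1C#Cc1ccc2c(n1)CCN(C)C2=O` carries a 2-methylphenyl group and a methyl on the lactam nitrogen. In an assay on HEK293 cells for displacement of a labelled ligand from metabotropic glutamate receptor 5 (Homo sapiens), with a stated time of 2 h (on this read-out higher numbers stand for weaker inhibition and lower numbers for stronger inhibition), compound 1 gives > 32000 nM, which is a limit of the assay rather than a number. Compound 2 `COc1cccc(C#Cc2ccc3c(n2)CCN(C)C3=O)c1` carries a methoxy on the phenyl ring, and in this assay compound 2 gives 3660 nM. Compound 3 `CC(C)N1CCc2nc(C#Cc3ccccc3)ccc2C1=O` has an unsubstituted phenyl and an isopropyl on the lactam nitrogen; in this assay compound 3 gives 1280 nM, the lowest of the two numbers shown, with compound 2 next by a gap beyond the usual scatter.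

Compound 4 `Cc1ccccc1C#Cc1ccc2c(n1)CCN(C(C)C)C2=O` is compound 3 with one change: methyl in place of hydrogen on an aromatic carbon, so that the phenyl becomes a 2-methylphenyl. Among the measured compounds shown here, no step between measured compounds isolates this change. For the measured compounds named here, still, compound 1, the only other compound with a 2-methylphenyl group, sits at the limit (the limit of > 32000 nM in this assay, at which 1 of the 3 values shown sits), which points toward a large loss of binding. The step from compound 3 to compound 4 is therefore expected to be a substantial rise in this assay, a 16-fold higher number from compound 3 to compound 4 (1.19 log units; beyond the scatter). Compound 4 is estimated at 20000 nM, within a range from 5000 nM to 60000 nM, with a real chance that only a limit is reported.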

Compound 4, inhibition constant: > 32000 nM
Compound 4 gave a limit, no number; the forecaster's own chance of this, stated with the estimate: 50%; middle value at least 1.6-fold (0.20 log units) away from the limit.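

In this assay, among the compounds shown here, a single methyl on an aromatic carbon, ortho to a large group, gives an at least 25-fold higher number from compound 3 to compound 4 (1.39 log units; beyond the scatter), a large step and the first direct view of this change, as no earlier pair of compounds isolated it. For the compounds shown here, until now, the only compound with a 2-methylphenyl group was compound 1, which also differs from compound 3 on the amide-type nitrogen, so its poor result could not be tied to the methyl alone. The 2-methylphenyl group has now been seen with methyl on that nitrogen in compound 1 and with isopropyl in compound 4, and the read-out for each of the two is a limit of the assay rather than a number: the limit of > 32000 nM in this assay, at which 2 of the 4 values shown sit.

Going by these compounds, the two limits make the step between compound 1 and compound 4 unreadable, and the true size of the loss from compound 3 stays unknown, as the step has only a lower bound. Also open, on these data alone, is how a fluorine, a hydroxyl or an amine on the same aromatic carbon would compare with the hydrogen of compound 3 and the methyl of compound 4.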